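The source may report more compounds than this note shows. Statements on the series, on what has been measured and on what is new or still open speak of the compounds shown alone.

Measured in a functional assay on HeLa cells (Homo sapiens) for antiproliferative activity, read by MTT assay, with a stated time of 48 h; on this read-out lower numbers stand for stronger inhibition and higher numbers for weaker inhibition:
- Compound 1 `COc1ccc(N(C)c2ccnc(Cl)n2)cc1F`: 241 nM
- Compound 2 `COc1ccc(N(C)c2ccnc(Cl)n2)cc1O`: 96 nM
- Compound 3 `COc1ccc(N(C)c2ccnc(Cl)n2)cc1OCCCBr`: 307 nM

Compound 3 stands with compound 1 at the weaker end of these three numbers, the two lying within the usual scatter of each other, while compound 2 has the lowest number.

The next compound, compound 4 `COc1ccc(N(C)c2ccnc(Cl)n2)cc1OCCCCCBr`, keeps everything in compound 3 except the end of the chain on the oxygen, where 3-bromopropyl becomes 5-bromopentyl: 2-bromoethyl in place of bromo on a saturated chain carbon, three bonds along the chain from an oxygen on an aromatic ring.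

Among the compounds with values here, no measured step changes the length of this chain, so the evidence is only indirect. Putting the chain on the free hydroxy gave a 3.2-fold higher number from compound 2 to compound 3 (0.50 log units; beyond the scatter), a modest step. Putting the chain in place of fluoro gave a 1.3-fold higher number from compound 1 to compound 3 (0.11 log units; within the scatter), which is no real change. Neither step says how a longer chain will behave. With so little to go on, no step beyond the scatter is expected in this assay, and no direction can be favoured with confidence. The expected change is a 1.1-fold higher number from compound 3 to compound 4 (0.03 log units; within the scatter). Compound 4 is estimated at 330 nM, with an expected range of 130 nM to 800 nM.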

Compound 4, half-maximal inhibitory concentration: 7090 nM
Estimate against measurement, compound 4: 21-fold (1.33 log units) below, and the stated range ends below it.
By their numbers in this assay, from the lowest: compound 2; then compounds 1 and 3 (each within the scatter of the next); then compound 4.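

Within this assay this position proves sensitive to the length of the chain on the oxygen: going from 3-bromopropyl to 5-bromopentyl gave a 23-fold higher number from compound 3 to compound 4 (1.36 log units; beyond the scatter) and is the first large step in the series, where every earlier step was modest or within the scatter. The longer chain also looks costly from the other two compounds, with a 74-fold higher number from compound 2 to compound 4 (1.87 log units; beyond the scatter) when 5-bromopentyl replaces the hydrogen on the oxygen and a 29-fold higher number from compound 1 to compound 4 (1.47 log units; beyond the scatter) when (5-bromopentyl)oxy replaces fluoro, so a change that was at most modest with 3-bromopropyl becomes a large one with 5-bromopentyl. Nothing available here bears on why the number climbs so steeply.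

With only these two chain lengths, the compounds shown leave open whether the number would rise gradually or jump suddenly, which a 4-bromobutyl chain or a longer chain such as 6-bromohexyl could help to settle. They also leave open whether the length alone matters or the bromo at the chain end takes part, a question that a plain pentyl chain or a pentyl chain ending in an amine could address.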